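Dithiocarbamate amides: amine swap at the thiocarbonyl carbon

The source may hold more compounds than are shown below. What is called first, only, known or untested is meant among the compounds shown, and "the series" means these compounds.

Measured so far in a functional assay on A-375 cells (Homo sapiens) for antiproliferative activity, read by CCK-8 assay, with a stated time of 72 h, tested at 2 uM; on this read-out higher numbers stand for a stronger effect at the one concentration tested and lower numbers for a weaker effect:
- compound 1 `Nc1ccccc1NC(=O)c1ccc(CSC(=S)N2CCN(C(c3ccccc3)c3ccccc3)CC2)cc1`: 8.7%
- compound 2 `Nc1ccccc1NC(=O)c1ccc(CSC(=S)N2CCCc3ccccc32)cc1`: 26.5%
- compound 3 `Nc1ccccc1NC(=O)c1ccc(CSC(=S)N2CCN(Cc3ccncc3)CC2)cc1`: 33.1%

Three compounds share the core of compound 2 and differ only in the amine bound to the thiocarbonyl carbon. Among the three numbers compound 2 stands second highest. Its nearest neighbour is compound 3, whose value lies within the scatter of that of compound 2, so no order between these two can be read. Its furthest neighbour is compound 1, whose value lies beyond the scatter below that of compound 2, so compound 2 is the more active of that pair.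

Compound 4 `CC1CCN(C(=S)SCc2ccc(C(=O)Nc3ccccc3N)cc2)CC1` is not yet measured. It differs from compound 2 in one place: 4-methylpiperidin-1-yl in place of 1,2,3,4-tetrahydroquinolin-1-yl on a thiocarbonyl carbon. Within the data shown here, no step between two measured compounds isolates this kind of exchange, so nothing in the numbers so far sets its direction. The two measured steps among the amines at this position range from none beyond the scatter to a clear drop, and the step from compound 2 to compound 4 is expected to stay within the scatter, a number 1.5 percentage points lower from compound 2 to compound 4 (within the scatter). For compound 4 in this assay the estimate is 25%, with a range from 10% to 40%.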

Compound 4, a percentage reported as inhibition, at one concentration (the size of the read-out at that concentration, not a potency): 32.7%
Compound 4: the middle estimate sits 7.7 percentage points below what was measured; the range from low to high includes it.
By their numbers in this assay, from the lowest: compound 1; then compounds 2, 4 and 3 (each within the scatter of the next).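

In this assay, among these compounds, the exchange of 1,2,3,4-tetrahydroquinolin-1-yl for 4-methylpiperidin-1-yl on a thiocarbonyl carbon gives the first single-place step between two measured compounds at this position, and it reads a number 6.2 percentage points higher from compound 2 to compound 4 (within the scatter); no order can be read from it. The six-membered aromatic ring of carbon only leaves with the 1,2,3,4-tetrahydroquinolin-1-yl group, yet compound 4 still gives 32.7%, so this ring is not needed for a value of this size at the one concentration tested. No measurement to hand bears on why the two amines read alike.

From the compounds shown here alone, whether a longer chain such as butyl, or a carboxylic acid, in place of the methyl of 4-methylpiperidin-1-yl would carry the number beyond the scatter remains open. Also open is whether an open-chain amine such as diethylamine on the thiocarbonyl carbon would hold the number of compound 4, and a read-out at a single concentration gives no potency for any of these compounds.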